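A methyl-to-bromo swap at the assay limit

This account rests on a few compounds, and the source may have more. Where it says the series, first, only, none or still open, it means among the compounds named here.

Values measured in an ADME assay on HEK293 cells (Homo sapiens) for cytotoxicity (on this read-out higher numbers stand for weaker inhibition and lower numbers for stronger inhibition), are as follows
- Compound 1 `COC(=O)c1c(C)cc(OC(=O)c2c(C)cc(O)c(/C=N/NC(=O)Cc3ccccc3)c2O)c(C)c1O` gives > 100000 nM as a limit
- Compound 2 `COC(=O)c1c(C)cc(OC(=O)c2c(C)cc(O)c(/C=N/NC(=O)COc3ccccc3C)c2O)c(C)c1O` gives > 100000 nM as a limit
- Compound 3 `COC(=O)c1c(C)cc(OC(=O)c2c(C)cc(O)c(/C=N/NC(=O)COc3ccc(C)cc3)c2O)c(C)c1O` gives > 100000 nM as a limit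

Compound 3 therefore has no exact number, and its position is shared by the whole set: the limit of > 100000 nM in this assay, at which 3 of the 3 values shown sit, applies here. Compound 4 `COC(=O)c1c(C)cc(OC(=O)c2c(C)cc(O)c(/C=N/NC(=O)COc3ccc(Br)cc3)c2O)c(C)c1O` carries bromo in place of methyl on an aromatic carbon and is otherwise the same. The closest measured steps are a step that the two limits leave unreadable from compound 2 to compound 3 and a step that the two limits leave unreadable from compound 1 to compound 3 and neither has a readable size or direction. The expected change is a number no higher from compound 3 to compound 4 (the limit leaves the size open) in this assay and no step beyond the scatter is expected. Compound 4 is estimated at 100000 nM with an expected range from 40000 nM to 150000 nM in this assay.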

Compound 4, half-maximal inhibitory concentration: > 100000 nM
Compound 4 was reported as a limit; the forecaster's own chance of this, stated with the estimate: 80%; the middle value sits exactly at the limit.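

Compound 4 gives only a limit, as do compound 1, compound 2 and compound 3, so no step among them can be read: the limit of > 100000 nM in this assay, at which 4 of the 4 values shown sit.

The compounds shown leave open whether bromo in place of methyl changes the read-out at all.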